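Swapping phenyl for isopropyl on a sulfur

This account rests on a few compounds, and the source may have more. Where it says the series, first, only, none or still open, it means among the compounds named here.

In a functional assay on HeLa cells (Homo sapiens) for antiproliferative activity, read by resazurin assay (a lower number here means a stronger inhibitor, a higher number a weaker inhibitor), compound 1 (`CSC(=S)SCC(=O)c1ccc(Cl)c(Cl)c1`) gives 6310 nM and compound 2 (`[C-]#[N+]c1ccc(C(=O)CSC(=S)SCC)cc1`) gives 7940 nM as its reading, two values within the usual scatter of each other. Compound 3 (`O=C(CSC(=S)Sc1ccccc1)c1ccc(Cl)c(Cl)c1`) gives 20000 nM as its reading, the highest number of the three and beyond the scatter from both others, which makes it the weakest inhibitor so far.

The next structure, compound 4 (`CC(C)SC(=S)SCC(=O)c1ccc(Cl)c(Cl)c1`), differs from compound 3 in one place (isopropyl in place of phenyl on a sulfur): isopropyl in place of phenyl on a sulfur. Among the measured compounds shown here, the one measured step that bears on this is a 3.2-fold higher number from compound 1 to compound 3 (0.50 log units; beyond the scatter) for phenyl in place of methyl on that same sulfur. Compound 4 removes that phenyl again, so the number is expected to fall, although isopropyl is not methyl and has no measurement of its own here. For the measured compounds named here, compound 2 differs from the others in more than one place and offers no clean step.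

In this assay the expected change is a 2.4-fold lower number from compound 3 to compound 4 (0.37 log units; beyond the scatter) as estimated, a little short of undoing the phenyl step. Compound 4 is estimated at 8500 nM with an expected range from 3500 nM to 20000 nM as the likely span.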

Compound 4, half-maximal inhibitory concentration: 25100 nM
Compound 4: the middle estimate sits 3.0-fold (0.47 log units) below what was measured; measured number outside the range, above it.
By their numbers in this assay, from the lowest: compounds 1 and 2 (each within the scatter of the next); then compounds 3 and 4 (each within the scatter of the next).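

In this assay, taking the phenyl away does not bring the number back down: the change reads as a 1.3-fold higher number from compound 3 to compound 4 (0.10 log units; within the scatter) and so leaves compound 3 and compound 4 indistinguishable, even though isopropyl has no ring and fewer heavy atoms than phenyl. Phenyl and isopropyl on this sulfur both stand apart from methyl, with a 3.2-fold higher number from compound 1 to compound 3 (0.50 log units; beyond the scatter) for one swap and a 4.0-fold higher number from compound 1 to compound 4 (0.60 log units; beyond the scatter) for the other, so among these three compounds the aromatic ring is not what separates the weaker pair from compound 1. Nothing measured here explains why two such different groups read alike.

From the compounds shown here alone, only methyl, phenyl and isopropyl can be compared on this sulfur with the rest of the core of compound 1 held fixed, so it remains open how sharply the number responds to the group there, and whether methyl sits at a real optimum. A longer chain such as butyl, or a chain ending in an amine or a carboxylic acid, would show whether any other group at this place can match methyl or improve on it.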